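Swapping trifluoroethoxy for ethoxy on a cyclopropane hydrazide

This account rests on a few compounds, and the source may have more. Where it says the series, first, only, none or still open, it means among the compounds named here.

Of the compounds shown here, three sharing a cyclopropane hydrazide core have been tested in a functional assay on PC-3 cells (Homo sapiens) for inhibition, read by MTT assay, with a stated time of 72 h; a lower number here means a stronger inhibitor, a higher number a weaker inhibitor. Compound 1 `O=C(NNC(=O)C1CC1c1ccc(OCC(F)(F)F)cc1)c1ccncc1` gives 44000 nM in this assay. Compound 2 `COc1ccc(C2CC2C(=O)NNc2nncc3ccccc23)cc1` gives 64000 nM, and compound 3 `CCOc1ccc(C2CC2C(=O)NNc2nncc3ccccc23)cc1` gives 94000 nM. Compound 1 sits at the low end of these three values: its gap to compound 2 is within the scatter, while its gap to compound 3 lies beyond it.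

The unmeasured compound 4 `CCOc1ccc(C2CC2C(=O)NNC(=O)c2ccncc2)cc1` keeps everything of compound 1 except one group. methyl in place of trifluoromethyl on a saturated chain carbon bound to an oxygen on an aromatic ring

Within the data shown here, only one measured step is available, and it concerns a related but different position on the same ether: a 1.5-fold higher number from compound 2 to compound 3 (0.17 log units; within the scatter). That step shows that growing the alkoxy chain by a methyl group barely moved the number. Among the measured compounds shown here, no measured pair shows the exchange of trifluoromethyl for methyl itself, so the direction of that change cannot be read from the data. Given how little the nearby change moved compound 2 to compound 3, compound 4 is expected to land close to compound 1, with the step of a 1.3-fold higher number from compound 1 to compound 4 (0.10 log units; within the scatter) likely staying within the scatter. The estimate for compound 4 in this assay is therefore 55000 nM, within a range from 25000 nM to 130000 nM.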

Compound 4, half-maximal inhibitory concentration: > 100000 nM
Compound 4 gave a limit, no number (the forecaster's own chance of this, stated with the estimate: 10%); middle value at least 1.8-fold (0.25 log units) from the limit.
By their numbers in this assay, from the lowest: compounds 1, 2 and 3 (each within the scatter of the next, the first and the last beyond it). At a limit, above all of these: compound 4.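

In this assay, compound 4 gives > 100000 nM, which is a limit and not a number. Even so, replacing trifluoromethyl with methyl on a saturated chain carbon bound to an oxygen on an aromatic ring gives an at least 2.2-fold higher number from compound 1 to compound 4 (0.35 log units; beyond the scatter), whereas the only earlier step on this ether, a 1.5-fold higher number from compound 2 to compound 3 (0.17 log units; within the scatter), stayed within the scatter and involved a different change on a different core. With the core of compound 1, the end of this ether chain therefore affects the number, with the 2,2,2-trifluoroethoxy group on the lower side of the pair, and the full size of the step remains unknown: the limit of > 100000 nM in this assay, at which 1 of the 4 values shown sits.

The compounds shown leave open whether swapping ethoxy for 2,2,2-trifluoroethoxy would have a similar effect on the core shared by compound 2 and compound 3. They also cannot tell whether all three fluorine atoms are needed, or how a 2-fluoroethyl group, a 2,2-difluoroethyl group or a longer chain such as propyl would compare at this position.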